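Working notes on a small cytotoxicity series

The compounds below may be only part of what the source reports. "The series", "measured", "known", "first", "only" and "open" are said of these compounds alone.

Measured compounds:
compound 1 `O=C(CCC1CCCCC1)Nc1ncc(Cc2ccccc2)s1`: > 40000 nM
compound 2 `CCc1cnc(NC(=O)CCC2CCCCC2)s1`: "not determined" (no result reported)
compound 3 `O=C(c1cnc(NC(=O)C2CCCCC2)s1)c1cccc2ccccc12`: > 40000 nM

In an ADME assay on P388D1 cells (Mus musculus) for cytotoxicity, read by fluorescence and resazurin assay, with a stated time of 72 h (a higher number here means a weaker inhibitor, a lower number a stronger inhibitor), compound 1 reaches only a limit of the assay, > 40000 nM. In this assay compound 3 also stops at a limit, > 40000 nM. For compound 2 nothing is reported in this assay ("not determined" (no result reported)), so compound 2 has no number of its own to stand on. The two other values in the set are limits, both sitting at the limit of > 40000 nM in this assay, at which 2 of the 3 values shown sit. For the measured compounds named here, no step between measured compounds can be read from this.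

Compound 4 `O=C(CCC1CCCCC1)Nc1ncc(Cc2ccncc2)s1` differs from compound 2 by pyridin-4-yl in place of methyl on a saturated chain carbon bound to an aromatic carbon. With compound 1 and compound 3 both at the limit and compound 2 without a value, no direction is given; any step from compound 2 to compound 4 in this assay is expected to be none beyond the scatter, and the result is more likely a limit than a number. Compound 4 is expected at about 40000 nM, with a range from 15000 nM to 100000 nM.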

Compound 4, half-maximal inhibitory concentration: > 40000 nM
Compound 4: a limit, no number; the forecaster's own chance of this, stated with the estimate: 75%; the middle value sits exactly at the limit.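

Compound 1 and compound 4 both stop at a limit in this assay, so no step between them can be read: the limit of > 40000 nM in this assay, at which 3 of the 4 values shown sit.

The compounds shown leave open whether pyridin-4-yl in place of phenyl has any effect in this assay, and whether any compound here gives a number rather than a limit.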